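Swapping the Amide for a Sulfonamide on the Shared Core

The source may hold more compounds than are shown below. What is called first, only, known or untested is meant among the compounds shown, and "the series" means these compounds.

Among the compounds with values here, compound 3 `COC1CC(C(=O)N2CCc3nc(C#Cc4ccccc4)sc3C2)C1` gives 640 nM in an assay on HEK293 cells for positive allosteric modulation of metabotropic glutamate receptor 5 (Homo sapiens), read by FLIPR, with a stated time of 1 h (on this read-out higher numbers stand for an effect only at larger amounts of compound and lower numbers for an effect already at smaller amounts), the highest of the two numbers known, with compound 2 `O=C(C1CC(F)C1)N1CCc2nc(C#Cc3ccccc3)sc2C1` at 85 nM. Compound 1 `CCC(=O)N1CCc2nc(C#Cc3ccccc3)sc2C1` shows only an assay limit, > 10000 nM. Compound 4 `CC(C)S(=O)(=O)N1CCc2nc(C#Cc3ccccc3)sc2C1` carries isopropylsulfonyl in place of (3-methoxycyclobutyl)carbonyl on an amine nitrogen in a ring. Within the data shown here, no measured step exchanges a carbonyl for a sulfonyl, so the change is untested here. The steps that exist went along with a four-membered ring entering: an at least 110-fold lower number from compound 1 to compound 2 (2.07 log units; beyond the scatter) and an at least 15-fold lower number from compound 1 to compound 3 (1.19 log units; beyond the scatter), while a 7.5-fold higher number from compound 2 to compound 3 (0.88 log units; beyond the scatter). Compound 4 has no ring in its new group, as in compound 1, where only a limit was seen (the limit of > 10000 nM in this assay, at which 1 of the 3 values shown sits). A rise in the number is therefore expected for compound 4, a 6.3-fold higher number from compound 3 to compound 4 (0.80 log units; beyond the scatter), and its value is estimated at 4000 nM, within 800 nM to 20000 nM.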

Compound 4, half-maximal effective concentration: > 10000 nM
Compound 4 ended at the assay's limit (the forecaster's own chance of this, stated with the estimate: 40%); middle value at least 2.5-fold (0.39 log units) away from the limit.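

On the amine nitrogen in a ring, isopropylsulfonyl gives an at least 15-fold higher number from compound 3 to compound 4 (1.19 log units; beyond the scatter) and an at least 110-fold higher number from compound 2 to compound 4 (2.07 log units; beyond the scatter), so this group does not keep the effect seen with either cyclobutyl carbonyl group. The step between compound 1 and compound 4 cannot be read: both values are limits. The two groups without a ring, propanoyl and isopropylsulfonyl, now end alike: the limit of > 10000 nM in this assay, at which 2 of the 4 values shown sit.

Compound 4 loses the ring and gains the sulfonyl in a single change, so the two cannot be told apart. A 3-fluorocyclobutylsulfonyl group on the same nitrogen would separate them.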